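Swapping the para substituent on the aryl ring of a xanthine

The source may report more compounds than this note shows. Statements on the series, on what has been measured and on what is new or still open speak of the compounds shown alone.

All three measured compounds share one core, a xanthine carrying an aromatic ring on its central carbon, and all were tested in an assay for binding affinity to adenosine receptor A1 (Bos taurus); a higher number here means a weaker inhibitor, a lower number a stronger inhibitor. Compound 1 `CCCn1c(=O)c2nc(-c3ccccc3N)[nH]c2n(CCC)c1=O` gives 0.75 nM. Compound 2 `Cn1c(=O)c2nc(-c3ccc(-c4ccccc4)cc3)[nH]c2n(C)c1=O` gives 3.5 nM. Compound 3 `CCOc1ccc(-c2nc3c(=O)n(C)c(=O)n(C)c3[nH]2)cc1` gives 2 nM. Compound 3 thus stands second of the three numbers: its gap to compound 2 lies within the scatter, while compound 1 sits beyond the scatter with the lower number.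

Compound 4 `Cn1c(=O)c2nc(-c3ccc([N+](=O)[O-])cc3)[nH]c2n(C)c1=O` is not yet measured. Compared with compound 3, the change is nitro in place of ethoxy on an aromatic carbon, placed on an aromatic carbon of a six-membered aromatic ring of carbon only, para to a large group.

Among the compounds with values here, the one measured step that bears on this position is the exchange of the group at that same place from compound 2 to compound 3, which gave a 1.8-fold lower number from compound 2 to compound 3 (0.24 log units; within the scatter). That single step says a change at this position can pass with little effect. Within the data shown here, no measured step covers a nitro group, so the expectation rests on that one comparison only.

Compound 4 is therefore expected to stay near compound 3, with a step of a 2.0-fold higher number from compound 3 to compound 4 (0.30 log units; within the scatter). The estimate for compound 4 in this assay is 4 nM, within a range from 1.2 nM to 13 nM.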

Compound 4, half-maximal inhibitory concentration: 8 nM
Estimate against measurement, compound 4: 2.0-fold (0.30 log units) below, and the stated range covers the measured number.
By their numbers in this assay, from the lowest: compound 1; then compounds 3 and 2 (each within the scatter of the next); then compound 4.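

Nitro in place of ethoxy brings a 4.0-fold higher number from compound 3 to compound 4 (0.60 log units; beyond the scatter) in this assay and nitro in place of phenyl brings a 2.3-fold higher number from compound 2 to compound 4 (0.36 log units; beyond the scatter) on the same shared core, so both steps lie beyond the scatter. The earlier exchange at this place, ethoxy in place of phenyl, stayed within the scatter, which made the position look open to any group; the new result shows that it is not indifferent to every change. Among the three groups tried here on this core, nitro gives the highest number and so the weakest inhibitor, while ethoxy and phenyl cannot be told apart, and nothing available explains what sets nitro apart from the other two.

The compounds shown leave open how an amine, a carboxylic acid or a chain longer than ethoxy would read at this same place on the ring. They also leave open whether nitro would bring a step of similar size on the core of compound 1, which differs from compound 4 in more than one place.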